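A few compounds are considered here, and "the series" means these few. Any claim that something is new, unique, unknown or untested is made for them only; others in the source may bear on it.

Compound 1 `CCOC(=O)c1csc2nc(CN3CCN(C)CC3)c(-c3ccc(OC)cc3)n12` and compound 2 `CCOC(=O)c1csc2nc(CN3CCN(C)CC3)c(-c3ccc(Br)cc3)n12` share one core; compound 3 `COc1ccc(-c2cnc3scc(C(=O)NNC(C)=O)n23)cc1` and compound 4 `CC(=O)NNC(=O)c1csc2ncc(-c3ccc(Br)cc3)n12` share another. The difference between the two cores is not broken down here. In a functional assay on HCT-116 cells (Homo sapiens) for antiproliferative activity, read by MTT assay, with a stated time of 72 h (on this read-out lower numbers stand for stronger inhibition and higher numbers for weaker inhibition), compound 1 gives 44600 nM, and compound 2 gives 93600 nM. Between them the change is bromo in place of methoxy on an aromatic carbon, and it made a 2.1-fold higher number from compound 1 to compound 2 (0.32 log units; beyond the scatter). In this assay compound 3 gives 17000 nM, the lowest number of the three measured. Going by the values given here, compound 4 differs from compound 3 by bromo in place of methoxy on an aromatic carbon; the change and its place read the same as the one from compound 1 to compound 2, so it is the same change, set on a different core. The step from compound 3 to compound 4 in this assay is expected to be a 2.1-fold higher number from compound 3 to compound 4 (0.33 log units; beyond the scatter), because on the other core the same change gave a 2.1-fold higher number from compound 1 to compound 2 (0.32 log units; beyond the scatter). Compound 4 is therefore estimated at 36000 nM, with a range of 15000 nM to 90000 nM.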

Compound 4, half-maximal inhibitory concentration: 6080 nM
For compound 4 the middle estimate is 5.9-fold (0.77 log units) above the measured one; the measured number lies below the stated range.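

In this assay, bromo in place of methoxy on an aromatic carbon gives a 2.8-fold lower number from compound 3 to compound 4 (0.45 log units; beyond the scatter). The step does not carry over between the two cores, and its direction reverses: the same change on two cores in this assay, a 2.1-fold higher number (0.32 log units; beyond the scatter) from compound 1 to compound 2 and a 2.8-fold lower number (0.45 log units; beyond the scatter) from compound 3 to compound 4, 5.9-fold (0.77 log units) apart, beyond the scatter of two such steps. This shows that, for these two pairs, the outcome of the change cannot be read from one core to the other, but with a single pair on each core it does not show why the steps differ or how the change would run on any further core.

Open, as far as these compounds go, is whether other groups at this place on the six-membered ring, such as chloro, methyl or an amine, would follow bromo or methoxy on either core. No pair shown isolates the difference between the two cores.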